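The source may hold more compounds than are shown below. What is called first, only, known or untested is meant among the compounds shown, and "the series" means these compounds.

Compound 1 `CCN(CC)C(=O)[C@@H]1CCCN(S(=O)(=O)c2ccc(S(=O)(=O)N(CC)CC)cc2)C1`: 10500 nM
Compound 2 `CCN(CC)C(=O)c1ccc(S(=O)(=O)N2CCC[C@@H](C(=O)N3CCN(c4nc(C(C)C)no4)CC3)C2)cc1`: 1400 nM

In a functional assay on BXPC-3 cells (Homo sapiens) for inhibition, read by MTT assay, with a stated time of 7 days (on this read-out higher numbers stand for weaker inhibition and lower numbers for stronger inhibition), compound 2 gives 1400 nM, the lower of the two numbers, while compound 1 gives 10500 nM, a gap that lies beyond the usual scatter. Compound 3 `CC(C)NS(=O)(=O)c1ccc(S(=O)(=O)N2CCC[C@@H](C(=O)N3CCN(c4nc(C(C)C)no4)CC3)C2)cc1` has not yet been measured; it differs from compound 2 by isopropylsulfamoyl in place of diethylcarbamoyl on an aromatic carbon. Within the data shown here, no single-change step between measured compounds sizes this exchange, so the shift from compound 2 to compound 3 in this assay is expected to be small, at most a slight weakening. Compound 3 is estimated at 2200 nM, within a range from 700 nM to 7000 nM. That corresponds to an expected step of a 1.6-fold higher number from compound 2 to compound 3 (0.20 log units; within the scatter).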

Compound 3, half-maximal inhibitory concentration: 2600 nM
Beside the measured number, compound 3's estimate is 1.2-fold (0.07 log units) below it, within the range that was stated.
By their numbers in this assay, from the lowest: compounds 2 and 3 (each within the scatter of the next); then compound 1.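

In this assay the exchange of diethylcarbamoyl for isopropylsulfamoyl on the aromatic carbon, para to a large group, gives a 1.9-fold higher number from compound 2 to compound 3 (0.27 log units; within the scatter) and provides the first single-change measure at this position. The number therefore stays within the scatter when a group with no hydrogen-bond donor gives way to one with a hydrogen-bond donor. Nothing measured here bears on the reason for this. The compounds shown leave open whether an amine, a carboxylic acid or a longer chain at this position would shift the number beyond the scatter.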